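The source may hold more compounds than are shown below. What is called first, only, known or untested is meant among the compounds shown, and "the series" means these compounds.

Measured so far:
- compound 1, `COc1ccc(Cl)c(-c2nnc3sc(-c4ccnc(Cl)c4)nn23)c1`: 20.2%
- compound 2, `COc1ccc(Cc2nnc3sc(-c4ccnc(Cl)c4)nn23)cc1OC`: 13.3%

Both were run in a functional assay on the whole organism (strain Wistar Albino) for inhibition, with Rattus norvegicus as the target, read by paw edema, with a stated time of 2 h, at a dose of 20 mg/kg; a higher number here means more inhibition at the dose given (going by the name of the read-out), a lower number less inhibition. Compound 1 gives 20.2% and compound 2 gives 13.3%; the two numbers lie within the scatter of each other, so compound 1 cannot be set apart from compound 2 on these data.

Compound 3, `COc1ccc(Cl)c(-c2nnc3sc(-c4ccnc(F)c4)nn23)c1`, is not yet measured. It differs from compound 1 by fluoro in place of chloro on an aromatic carbon, read one bond further out as 2-chloropyridin-4-yl to 2-fluoropyridin-4-yl. Among the measured compounds shown here, no measured pair shows this change, so nothing beyond the scatter is expected in this assay, in either direction. Compound 3 is estimated at 18%, range 5% to 35%, an expected step of a number 2.2 percentage points lower from compound 1 to compound 3 (within the scatter).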

Compound 3, a percentage reported as inhibition, in the whole organism at one dose (the size of the read-out at that dose, not a potency): 24.7%
Compound 3: the middle estimate sits 6.7 percentage points below what was measured, within the range that was stated.
By their numbers in this assay, from the lowest: compounds 2, 1 and 3 (each within the scatter of the next, the first and the last beyond it).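

Fluoro in place of chloro on this aromatic carbon gives a number 4.5 percentage points higher from compound 1 to compound 3 (within the scatter) in this assay, the first step in the series read at a single place. At this dose, 2-chloropyridin-4-yl and 2-fluoropyridin-4-yl therefore cannot be told apart, and the halogen exchange shows no readable effect at this position. No measurement at hand bears on the reason for this result.

Still open, on these data alone, is whether an amine or a carboxylic acid on this carbon would move the number beyond the scatter. Also open, as far as these compounds go, is whether the same exchange behaves alike on the core of compound 2.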